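The source may report more compounds than this note shows. Statements on the series, on what has been measured and on what is new or still open speak of the compounds shown alone.

Going by the values given here, compound 2 `O=C(Nc1ccc2cccnc2c1)c1ccc(-c2ccc(Cl)cc2)nc1` gives the only plain number here: in an in vitro functional assay on 1321-N1 cells for antagonist activity at transient receptor potential cation channel subfamily V member 1 (Homo sapiens), read by FLIPR and calcium flux (a lower number here means a less potent compound, a higher number a more potent compound, by a factor of ten per unit of this negative logarithm), compound 2 reaches 7.8. Compound 1 `N#Cc1ccc(C(=O)Nc2ccc3cccnc3c2)cn1` stands at a limit of the assay, since in this assay compound 1 shows < 6.7, a limit rather than a number (the limit of < 6.7 in this assay, at which 1 of the 2 values shown sits). Among the compounds with values here, the one measured step, a number at least 1.10 log units higher from compound 1 to compound 2 (beyond the scatter), is large but concerns a different change. Compound 3 `O=C(Nc1ccc2cccnc2c1)c1ccc(-c2ccc(F)cc2)nc1` differs from compound 2 by fluoro in place of chloro on an aromatic carbon. Within the data shown here, no measured step shows this swap, so compound 3 is expected to move little, a number 0.20 log units lower from compound 2 to compound 3 (within the scatter), with an estimated value of 7.6 ranging from 7.1 to 8.1.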

Compound 3, negative logarithm of the antagonist equilibrium constant: 8.2
Compound 3: middle estimate off by 0.60 log units, on the low side; measured number outside the range, above it.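

On this aromatic carbon, para to a large group, the choice of halogen on the ring is not neutral: in this assay the swap of chloro for fluoro gives a number 0.40 log units higher from compound 2 to compound 3 (beyond the scatter) and so separates two single-atom groups. Replacing cyano with 4-fluorophenyl gives a number at least 1.50 log units higher from compound 1 to compound 3 (beyond the scatter) and so extends the large step already seen with 4-chlorophenyl. That step is only a bound, as compound 1 stands at a limit: the limit of < 6.7 in this assay, at which 1 of the 3 values shown sits. The compounds shown leave open how a methoxy group, an amine or a plain hydrogen would read at this position. They also leave open whether fluoro keeps its edge over chloro on another core.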